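The source may report more compounds than this note shows. Statements on the series, on what has been measured and on what is new or still open speak of the compounds shown alone.

In a functional assay on COLO 205 cells (Homo sapiens) for inhibition, read by sulforhodamine B assay, with a stated time of 48 h, tested at 50 uM (a lower number here means less inhibition of growth, a higher number more inhibition of growth at the concentration tested), compound 1 `COc1cccc(/C=C/C(=O)/C=C/c2ccc(OCc3cn(CCCCOc4cc(=O)oc5ccccc45)nn3)c(OC)c2)c1` gives 46% and compound 2 `COc1cccc(/C=C/C(=O)/C=C/c2ccc(OCc3cn(CCOc4cc(=O)oc5ccccc45)nn3)c(OC)c2)c1` gives 69%, so compound 2 holds the higher of the two numbers, with a gap beyond the usual scatter. Compound 3 `COc1ccccc1/C=C/C(=O)/C=C/c1ccc(OCc2cn(CCOc3cc(=O)oc4ccccc34)nn2)c(OC)c1` has the same atoms as compound 2, joined differently: 2-methoxyphenyl in place of 3-methoxyphenyl on a double-bonded chain carbon bound to a double-bonded chain carbon. In words, 2-methoxyphenyl stands in place of 3-methoxyphenyl on a double-bonded chain carbon bound to a double-bonded chain carbon. Among the measured compounds shown here, no measured pair shows this kind of change, so only a small drop, within the scatter, is expected in this assay. The estimated step is a number 6 percentage points lower from compound 2 to compound 3 (within the scatter). For compound 3 the expected value is 63%, with an estimated range of 43% to 82%.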

Compound 3, percent growth inhibition at one concentration: 67%
Beside the measured number, compound 3's estimate is 4 percentage points below it; the range from low to high includes it.
By their numbers in this assay, from the lowest: compound 1; then compounds 3 and 2 (each within the scatter of the next).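

In this assay, 2-methoxyphenyl in place of 3-methoxyphenyl gives a number 2 percentage points lower from compound 2 to compound 3 (within the scatter), so the two compounds cannot be told apart at the concentration tested. Among the compounds shown here, this is the first reading of a change on this aryl group, and both methoxyphenyl forms are tolerated on a double-bonded chain carbon bound to a double-bonded chain carbon. No measurement here offers an explanation for this result. The compounds shown leave open how an unsubstituted phenyl, a hydroxyphenyl or an aminophenyl would behave in this place.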